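Trimming the halogens from an inactive biaryl ether

A few compounds are considered here, and "the series" means these few. Any claim that something is new, unique, unknown or untested is made for them only; others in the source may bear on it.

Measured so far, in an assay on HEK293 cells for positive allosteric modulation of metabotropic glutamate receptor 2 (Rattus norvegicus), read by thallium flux; a lower number here means that less compound is needed, a higher number that more compound is needed for the effect:
Compound 1 `O=C(O)c1cc(-c2cccc(COc3ccc4c(c3)CN(C3CCCC3)C4=O)c2)ccc1O` gives 20 nM.
Compound 2 `COc1ccc(-c2cccc(COc3ccc4c(c3)CN(C3CCCC3)C4=O)c2)cc1C(=O)O` gives 170 nM.
Compound 3 `O=C1c2ccc(OCc3cccc(-c4ccc(Cl)cc4F)c3)cc2CN1C1CCCC1` gives > 5000 nM, which is a limit of the assay rather than a number.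

Compound 3 therefore sits at the limit of > 5000 nM in this assay, at which 1 of the 3 values shown sits, and it is the weakest of the three, since its steps from both other compounds lie beyond the scatter. The next compound, compound 4 `O=C1c2ccc(OCc3cccc(-c4ccccc4)c3)cc2CN1C1CCCC1`, differs from compound 3 in one place: phenyl in place of 4-chloro-2-fluorophenyl on an aromatic carbon.

Among the compounds with values here, two measured steps bear on this. The step of an at least 250-fold higher number from compound 1 to compound 3 (2.39 log units; beyond the scatter) and the step of an at least 29-fold higher number from compound 2 to compound 3 (1.46 log units; beyond the scatter) both show that exchanging a phenyl carrying a carboxy group and a hydroxy or methoxy group for the 4-chloro-2-fluorophenyl costs a large amount of potency. Compound 4 carries a plain phenyl, so it too lacks the carboxy-bearing group that compounds 1 and 2 share. The expectation is that compound 4 stays at or near the limit, with an expected step that the limit leaves unreadable from compound 3 to compound 4 that cannot be resolved against a limit. In this assay compound 4 is estimated at 9000 nM, in a range from 2500 nM to 40000 nM, most likely reported only as a limit.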

Compound 4, half-maximal effective concentration: > 5000 nM
Compound 4 ended at the assay's limit; the forecaster's own chance of this, stated with the estimate: 75%; the middle value lies beyond the limit too.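

In this assay, the 4-chloro-2-fluorophenyl of compound 3 can give way to a plain phenyl in compound 4, and the value still stands at the assay's limit, not at a number: the limit of > 5000 nM in this assay, at which 2 of the 4 values shown sit. With two limits, the step from compound 3 to compound 4 cannot be read, so no size can be given for taking away the chlorine and the fluorine. What is new is that the poor result at this place needs neither halogen, for the plain phenyl also falls far short of the rings that carry a carboxy group, with an at least 29-fold higher number from compound 2 to compound 4 (1.46 log units; beyond the scatter) and an at least 250-fold higher number from compound 1 to compound 4 (2.39 log units; beyond the scatter).

The compounds shown leave open which part of the 3-carboxy-4-hydroxyphenyl group of compound 1 matters: the carboxylic acid, the hydroxy group, or the two together. Also open, from the compounds shown here alone, is whether another group on this phenyl, such as an amine or a sulfonamide, could bring back a readable value in this assay.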